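The source may hold more compounds than are shown below. What is called first, only, known or untested is meant among the compounds shown, and "the series" means these compounds.

Compound 2 (`COc1ccc(S(=O)(=O)c2nc3ccccc3nc2N2CCc3ccccc3C2)cc1`) belongs to a small set with compound 1 (`O=S(=O)(c1ccccc1)c1nc2ccccc2nc1N1CCc2ccccc2C1`) and compound 3 (`O=S(=O)(c1ccc(F)cc1)c1nc2ccccc2nc1N1CCc2ccccc2C1`). In a functional assay on HCT-116 cells (Homo sapiens) for cytotoxicity, read by MTT assay, with a stated time of 72 h (on this read-out higher numbers stand for weaker inhibition and lower numbers for stronger inhibition), the numbers sit close together: compound 1 (18700 nM), compound 2 (22100 nM) and compound 3 (16600 nM). Compound 2 therefore stands level with the other two, with no real order among them.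

Compound 4 (`COc1ccc(S(=O)(=O)c2nc3ccccc3nc2N2CCC(O)CC2)cc1`) keeps the methoxy of compound 2, but 4-hydroxypiperidin-1-yl comes in place of 1,2,3,4-tetrahydroisoquinolin-2-yl on an aromatic carbon (4-hydroxypiperidin-1-yl in place of 1,2,3,4-tetrahydroisoquinolin-2-yl on an aromatic carbon).

The measured steps are all small: there is a 1.2-fold higher number from compound 1 to compound 2 (0.07 log units; within the scatter) and a 1.1-fold lower number from compound 1 to compound 3 (0.05 log units; within the scatter) and also a 1.3-fold lower number from compound 2 to compound 3 (0.12 log units; within the scatter) among the swaps of hydrogen, methoxy and fluoro. For the measured compounds named here, all three compounds carry the same 1,2,3,4-tetrahydroisoquinolin-2-yl, so no measured step shows what replacing it does. Going by the values given here, the guidance is therefore weak, and no step clearly beyond the scatter is expected, with only a slight lean towards a higher number.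

In this assay the expected step is a 1.4-fold higher number from compound 2 to compound 4 (0.13 log units; within the scatter) and this remains a tentative call. For compound 4 the estimated value is 30000 nM with an expected range from 11000 nM to 80000 nM as the likely span.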

Compound 4, half-maximal inhibitory concentration: 4690 nM
The estimate for compound 4 lay 6.4-fold (0.81 log units) above the measured number, and the stated range ends above it.
By their numbers in this assay, from the lowest: compound 4; then compounds 3, 1 and 2 (each within the scatter of the next).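

In this assay, the step with 4-hydroxypiperidin-1-yl in place of 1,2,3,4-tetrahydroisoquinolin-2-yl is a 4.7-fold lower number from compound 2 to compound 4 (0.67 log units; beyond the scatter) and shows that this position, on the aromatic carbon next to the ring nitrogen, can move the number beyond the scatter, which the swaps of hydrogen, methoxy and fluoro among compound 1, compound 2 and compound 3 did not do. The entering group lacks the six-membered aromatic ring and brings a hydrogen-bond donor, so two differences travel together in this single step. No evidence is at hand on why the number fell.

Going by these compounds, it remains open whether the hydroxy counts on its own, which an unsubstituted piperidine or a morpholine at this position would help to show. On these data alone, it is also open whether the step holds with hydrogen or fluoro in place of the methoxy.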